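The source may report more compounds than this note shows. Statements on the series, on what has been measured and on what is new or still open speak of the compounds shown alone.

Measured so far:
- Compound 1 `CCCN(c1ccncc1)n1cccc1Cl`: > 20 mg/kg (a limit)
- Compound 2 `CN(c1ccncc1)n1cccc1C=O`: > 20 mg/kg (a limit)

Both results in a functional assay on the whole organism with Mus musculus as the target (a higher number here means that more compound is needed for the effect, a lower number that less compound is needed), are limits and not numbers (the limit of > 20 mg/kg in this assay, at which 2 of the 2 values shown sit). Compound 2 therefore has only the limit > 20 mg/kg as its standing.

Compound 3 `CCCN(c1ccncc1)n1cccc1C=O` differs from compound 2 by ethyl in place of hydrogen on a saturated chain carbon bound to a nitrogen on an aromatic ring, which also reads as methyl to propyl.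

Among the measured compounds shown here, no measured step shows what this change does, so no change beyond the scatter is expected in this assay. The expected step is a number no higher from compound 2 to compound 3 (the limit leaves the size open). For compound 3 the estimated value is 20 mg/kg, with an expected range from 7 mg/kg to 40 mg/kg.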

Compound 3, dose for half-maximal effect: > 20 mg/kg
Compound 3: no number, only a limit; the forecaster's own chance of this, stated with the estimate: 60%; the middle value sits exactly at the limit.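

No step can be read from compound 2 to compound 3 or from compound 1 to compound 3 in this assay, because all three results are limits: the limit of > 20 mg/kg in this assay, at which 3 of the 3 values shown sit. The compounds shown leave open what dose any of them would need, and so what either change does.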